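Aryl replacement on the shared core: expectation for compound 4

A few compounds are considered here, and "the series" means these few. Any claim that something is new, unique, unknown or untested is made for them only; others in the source may bear on it.

Compound 3 `Cc1cc(Cl)cc(-c2c(C)nn(-c3nc(-c4ccc(Cl)c(Cl)c4)c(SC(C)C)s3)c2C(=O)O)c1` gives 663 nM in a functional assay on BJAB cells (Homo sapiens) for antiproliferative activity, with a stated time of 4 days (a lower number here means that less compound is needed, a higher number that more compound is needed for the effect), the lowest number of the three measured. Compound 1 `Cc1cc(C)cc(-c2c(C)nn(-c3nc(-c4ccc(Cl)c(Cl)c4)c(SC(C)C)s3)c2C(=O)O)c1` gives 2700 nM in this assay, and compound 2 `COc1cncc(-c2c(C)nn(-c3nc(-c4ccc(Cl)c(Cl)c4)c(SC(C)C)s3)c2C(=O)O)c1` gives 21000 nM. Compound 4 `Cc1nn(-c2nc(-c3ccc(Cl)c(Cl)c3)c(SC(C)C)s2)c(C(=O)O)c1-c1cccc(C(F)(F)F)c1` differs from compound 3 by 3-(trifluoromethyl)phenyl in place of 3-chloro-5-methylphenyl on an aromatic carbon. Among the compounds with values here, no measured step covers a trifluoromethyl-bearing ring; the nearest are a 4.1-fold lower number from compound 1 to compound 3 (0.61 log units; beyond the scatter), a 7.8-fold higher number from compound 1 to compound 2 (0.89 log units; beyond the scatter) and a 32-fold lower number from compound 2 to compound 3 (1.50 log units; beyond the scatter), all beyond the scatter and all tied to the same aryl position. With compound 3 holding the lowest number and the new ring untested, a modest upward step is expected, a 2.3-fold higher number from compound 3 to compound 4 (0.35 log units; beyond the scatter). Compound 4 is estimated at 1500 nM in this assay, with a range from 500 nM to 5000 nM.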

Compound 4, half-maximal effective concentration: 22000 nM
Estimate against measurement, compound 4: 15-fold (1.17 log units) below; the whole stated range lies below it.
By their numbers in this assay, from the lowest: compound 3; then compound 1; then compounds 2 and 4 (each within the scatter of the next).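

The aryl position is more sensitive than compounds 1 to 3 showed: in this assay the change gives a 33-fold higher number from compound 3 to compound 4 (1.52 log units; beyond the scatter), so a six-membered aromatic ring of carbon only does not by itself keep the number low. The step of a 1.0-fold higher number from compound 2 to compound 4 (0.02 log units; within the scatter) puts this ring level with 5-methoxypyridin-3-yl, and an 8.1-fold higher number from compound 1 to compound 4 (0.91 log units; beyond the scatter) places it clearly on the high side of 3,5-dimethylphenyl. Nothing available explains this difference between the rings.

Compound 4 differs from compound 3 in more than one ring substituent, so the contribution of trifluoromethyl itself stays unresolved. Also open, as far as these compounds go, is how a nitrile or an amine on this ring would compare.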